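This account rests on a few compounds, and the source may have more. Where it says the series, first, only, none or still open, it means among the compounds named here.

Series notes, tertiary anilines on a shared core.

Compound 1 `COc1ccc(CNc2cc(OC)c(OC)c(OC)c2)cc1Br` carries hydrogen on the nitrogen and gives 39800 nM in a functional assay on KYSE-450 cells (Homo sapiens) for inhibition, read by MTT assay, with a stated time of 48 h; on this read-out higher numbers stand for weaker inhibition and lower numbers for stronger inhibition. Compound 2 `C#CC(=O)N(Cc1ccc(OC)c(O)c1)c1cc(OC)c(OC)c(OC)c1` gives 570 nM in this assay. Compound 3 `C/C=C/C(=O)N(Cc1ccc(OC)c(Br)c1)c1cc(OC)c(OC)c(OC)c1` gives 10500 nM in this assay, the second highest of the three numbers, closest to compound 1 and furthest from compound 2. Going by the values given here, the only single-place step measured is a 3.8-fold lower number from compound 1 to compound 3 (0.58 log units; beyond the scatter), the (prop-1-en-1-yl)carbonyl in place of hydrogen on a nitrogen on an aromatic ring. Compound 2 differs from compound 3 in two places at once, so its much lower number cannot be assigned to either change.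

Compound 4 `C/C=C/C(=O)N(Cc1ccc(OC)cc1)c1cc(OC)c(OC)c(OC)c1` is the next step: hydrogen in place of bromo on an aromatic carbon, a 3-bromo-4-methoxyphenyl becoming a 4-methoxyphenyl. Among the compounds with values here, no measured step touches this aromatic carbon, so there is no direct precedent. A step of a 1.4-fold higher number from compound 3 to compound 4 (0.15 log units; within the scatter) is expected, which is to say no shift beyond the scatter, with some allowance for a modest rise. Compound 4 is therefore estimated at 15000 nM, between 5000 nM and 45000 nM.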

Compound 4, half-maximal inhibitory concentration: 420 nM
Beside the measured number, compound 4's estimate is 36-fold (1.55 log units) above it, outside the stated range (below it).
By their numbers in this assay, from the lowest: compounds 4 and 2 (each within the scatter of the next); then compound 3; then compound 1.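

Going by these compounds alone, the bromo on this aromatic carbon, ortho to a methoxy group, is the first single-place change to produce a large step in this assay: a 25-fold lower number from compound 3 to compound 4 (1.40 log units; beyond the scatter), set against the modest 3.8-fold lower number from compound 1 to compound 3 (0.58 log units; beyond the scatter) at the nitrogen. With the (prop-1-en-1-yl)carbonyl on the nitrogen held fixed, the change from 3-bromo-4-methoxyphenyl to 4-methoxyphenyl therefore counts for more than the acylation step measured so far. No available evidence bears on the reason for this step.

Going by these compounds, it remains open whether a fluoro or an amine on this carbon would give a number nearer that of compound 3 or that of compound 4. On these data alone, it is also open whether the same step would appear with the acyl group of compound 2 or with hydrogen on the nitrogen, as in compound 1.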